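Chloro removal on the benzyl ether of compound 2

The source may hold more compounds than are shown below. What is called first, only, known or untested is meant among the compounds shown, and "the series" means these compounds.

Three compounds have been run in a functional assay on SMMC-7721 cells (Homo sapiens) for inhibition, read by MTT assay, with a stated time of 72 h, tested at 1 uM; a higher number here means a stronger effect of the compound at the concentration tested, a lower number a weaker effect. Compound 1 `Cc1cccc(COc2ccc(/C=C/C(/C=C/c3ccccn3)=N/Oc3ncnc4ccccc34)cc2)c1` gives 69.2%, compound 3 `Cc1cccc(COc2ccc(/C=C/C(/C=C/c3ccccn3)=N/Oc3ncnc4cc(Cl)ccc34)cc2)c1` gives 78.6%, and compound 2 `Cc1cccc2ncnc(O/N=C(\C=C\c3ccccn3)/C=C/c3ccccc3OCc3ccc(Cl)cc3Cl)c12` gives 90.8%, the highest of the three, with compound 3 nearest and compound 1 furthest. The difference between the cores of compound 2 and compound 3 is not broken down here. Within the measured set one single-point change occurs, (hydrogen in place of chloro on an aromatic carbon), which gave a number 9.4 percentage points lower from compound 3 to compound 1 (within the scatter).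

Compound 4 `Cc1cccc2ncnc(O/N=C(\C=C\c3ccccn3)/C=C/c3ccccc3OCc3ccc(Cl)cc3)c12` is unmeasured. It arises from compound 2 by the same kind of change, (hydrogen in place of chloro on an aromatic carbon), though the surroundings differ: in compound 3 the carbon sits in a six-membered aromatic ring of carbon only that is part of a fused or bridged system of two rings, meta to a fused ring and para to a fused ring, whereas in compound 2 it sits in a six-membered aromatic ring of carbon only, ortho to a large group and meta to a chloro group. Compound 4 is expected to show a step of a number 6.8 percentage points lower from compound 2 to compound 4 (within the scatter) because a number 9.4 percentage points lower from compound 3 to compound 1 (within the scatter). Compound 4 is therefore estimated at 84%, between 70% and 94%.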

Compound 4, a percentage reported as inhibition, at one concentration (the size of the read-out at that concentration, not a potency): 93.4%
Estimate against measurement, compound 4: 9.4 percentage points below; measured number inside the range.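

In this assay, the exchange of (2,4-dichlorobenzyl)oxy for (4-chlorobenzyl)oxy gives a number 2.6 percentage points higher from compound 2 to compound 4 (within the scatter). Set beside the earlier case of hydrogen in place of chloro, on another aromatic ring and another core, the result gives no sign that the core alters the outcome of this change: the same change on two cores in this assay, a number 9.4 percentage points lower (within the scatter) from compound 3 to compound 1 and a number 2.6 percentage points higher (within the scatter) from compound 2 to compound 4, 12 percentage points apart, within the scatter of two such steps This is no proof that the change carries over with a fixed size or direction, since neither step can be told from the scatter, only two pairs are available, the chloro sits in a different place in each pair, and the read-out comes from a single concentration and is not a potency.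

Still open, from the compounds shown here alone, is what the chloro that remains in compound 4 contributes, which a plain benzyl ether on the same core would address. Also open, going by these compounds, is how a methoxy group, a nitrile or an amine would read in place of chloro on this ring.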